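A few compounds are considered here, and "the series" means these few. Any claim that something is new, unique, unknown or untested is made for them only; others in the source may bear on it.

Compound 1 `CCc1ccc(-n2nc(-c3ccc(C(F)(F)F)cc3O)nc2-c2ccccc2O)cc1`: 57000 nM
Compound 2 `COc1cccc(-n2nc(-c3ccc(C(F)(F)F)cc3O)nc2-c2ccccc2O)c1`: 81100 nM

These two compounds were tested in a toxicity assay on HaCaT cells (Homo sapiens) for cytotoxicity, read by MTT assay; on this read-out lower numbers stand for stronger inhibition and higher numbers for weaker inhibition. Compound 2 stands within the scatter of compound 1, so neither can be ranked above the other. Compound 3 `Cc1cc(C)cc(-n2nc(-c3ccc(C(F)(F)F)cc3O)nc2-c2ccccc2O)c1` is still to be measured. It carries 3,5-dimethylphenyl in place of 3-methoxyphenyl on an aromatic nitrogen. The shared core and the 2-hydroxyphenyl group stay unchanged.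

Among the compounds with values here, only one measured step bears on this position: a 1.4-fold higher number from compound 1 to compound 2 (0.15 log units; within the scatter). That exchange, 3-methoxyphenyl in place of 4-ethylphenyl, stayed within the scatter, so no step beyond the scatter is expected here, though a single step is thin evidence. The expected step, a 1.2-fold lower number from compound 2 to compound 3 (0.08 log units; within the scatter), is therefore small. For compound 3 the estimated value is 68000 nM, with an expected range from 35000 nM to 130000 nM.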

Compound 3, half-maximal inhibitory concentration: 127000 nM
The estimate for compound 3 lay 1.9-fold (0.27 log units) below the measured number; the measured number falls inside the stated range.
By their numbers in this assay, from the lowest: compounds 1, 2 and 3 (each within the scatter of the next, the first and the last beyond it).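

In this assay, putting 3,5-dimethylphenyl in place of 3-methoxyphenyl on the aromatic nitrogen gives a 1.6-fold higher number from compound 2 to compound 3 (0.19 log units; within the scatter), so this exchange alone cannot be told apart from repeat scatter. The position does, however, now show its first step beyond the scatter, a 2.2-fold higher number from compound 1 to compound 3 (0.35 log units; beyond the scatter), a modest one that shows the choice of aryl group here can register in this read-out. Nothing at hand accounts for either step.

As far as these compounds go, it remains open whether a carboxylic acid or an amine on this aryl group, or a longer chain in place of the ethyl group, would carry the numbers in this assay further in either direction. The compounds shown also leave open what the 2-hydroxyphenyl group and the trifluoromethyl group contribute, since both stay the same throughout.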